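Swapping a Butyl Chain for a Pentylphenyl Ring

A few compounds are considered here, and "the series" means these few. Any claim that something is new, unique, unknown or untested is made for them only; others in the source may bear on it.

Of the compounds shown here, three have so far been tested in a functional assay on L1210 cells (Mus musculus) for antiproliferative activity, read by MTT assay, with a stated time of 2 days; a lower number here means a stronger inhibitor, a higher number a weaker inhibitor. Compound 1 `CCCCCCCCC#Cc1cn(C/C=C\CN2C(=O)c3ccccc3C2=O)c(=O)[nH]c1=O` gives 45000 nM, compound 2 `CCCCC#Cc1cn(C/C=C\CN2C(=O)c3ccccc3C2=O)c(=O)[nH]c1=O` gives 109000 nM, and compound 3 `CCCCC#Cc1cn(C/C=C/CN2C(=O)c3ccccc3C2=O)c(=O)[nH]c1=O` gives 236000 nM. Compound 3 thus has the highest number of the three and is the weakest inhibitor measured so far. Two steps lead to it: a 2.4-fold higher number from compound 1 to compound 2 (0.38 log units; beyond the scatter), and a 2.2-fold higher number from compound 2 to compound 3 (0.34 log units; beyond the scatter). The second of these follows from the fact that compounds 2 and 3 differ only in the configuration as drawn.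

Compound 4 `CCCCCc1ccc(C#Cc2cn(C/C=C/CN3C(=O)c4ccccc4C3=O)c(=O)[nH]c2=O)cc1` has not yet been measured. It differs from compound 3 by 4-pentylphenyl in place of butyl on a triple-bonded carbon. The step from compound 1 to compound 2 is the one that bears on this change, since it also alters the group carried by the triple-bonded carbon: there, losing a butyl gave a modestly higher number. A larger group entering at the same carbon is therefore expected to give a modestly lower number. Compound 4 is expected to give 80000 nM, with a range from 20000 nM to 300000 nM. This corresponds to an expected step of a 3.0-fold lower number from compound 3 to compound 4 (0.47 log units; beyond the scatter).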

Compound 4, half-maximal inhibitory concentration: 39000 nM
Compound 4: the middle estimate sits 2.1-fold (0.31 log units) above what was measured; low and high end bracket the measured number.
By their numbers in this assay, from the lowest: compounds 4 and 1 (each within the scatter of the next); then compound 2; then compound 3.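

The carbon at the end of the triple bond accepts far more than a saturated chain: with 4-pentylphenyl, 11 heavy atoms against the 4 of butyl, and an aromatic ring in place of no ring, this assay gives a 6.1-fold lower number from compound 3 to compound 4 (0.78 log units; beyond the scatter). The earlier compounds shown here showed a change at this carbon only as a saturated chain on the Z double bond, whereas this step shows that a larger group also lowers the number on the E double bond, and that the group need not be a simple chain. Nothing measured here accounts for why this swap lowers the number.

The compounds shown leave open whether the aromatic ring or the pentyl chain on it matters more, a question that a plain phenyl group or a phenyl ring carrying an amine could address. On these data alone, it also remains open whether the 4-pentylphenyl group would give a similar step on the Z double bond.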